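The compounds below may be only part of what the source reports. "The series", "measured", "known", "first", "only" and "open" are said of these compounds alone.

- compound 1 `Cc1ccsc1/C=C(/SCc1ccc(Cl)c(Cl)c1)C(=O)c1ccc(Cl)cc1` gives 50000 nM
- compound 2 `COc1cc(OC)c(/C=C(\C(=O)c2ccc(Br)cc2)S(=O)(=O)c2ccc(Br)cc2)c(OC)c1` gives > 100000 nM (a limit)
- compound 3 `O=C(/C(=C\c1ccccc1OCc1ccccc1)S(=O)(=O)c1ccc(F)cc1)c1ccc(Cl)cc1` gives 1000 nM

These results come from a functional assay on DU-145 cells (Homo sapiens) for inhibition, read by trypan blue exclusion, with a stated time of 96 h; a higher number here means a weaker inhibitor of growth, a lower number a stronger inhibitor of growth. For compound 2 the result > 100000 nM is a limit of the assay, not a number. That leaves two true numbers. Compound 3 has the lower one at 1000 nM and stands well clear of compound 1 at 50000 nM in a gap beyond the usual scatter.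

Compound 4 `O=C(/C(=C\c1ccccc1OCc1ccccc1)S(=O)(=O)c1ccc(Br)cc1)c1ccc(Cl)cc1` differs from compound 3 in one place only, para to a large group (bromo in place of fluoro on an aromatic carbon). Among the measured compounds shown here, no two measured compounds differ by a single change, so the data offer no direct guide to this swap. With so small an edit, the starting point remains compound 3 at 1000 nM in this assay. The expected step of a 1.2-fold higher number from compound 3 to compound 4 (0.08 log units; within the scatter) stays within the scatter, and neither direction is favoured. Compound 4 is expected at 1200 nM with 350 nM to 5000 nM as the estimated range.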

Compound 4, concentration for 50% growth inhibition: 1000 nM
Compound 4: middle estimate off by 1.2-fold (0.08 log units), on the high side; low and high end bracket the measured number.
By their numbers in this assay, from the lowest: compounds 3 and 4 (each within the scatter of the next); then compound 1. At a limit, above all of these: compound 2.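

In this assay, exchanging 4-fluorophenyl for 4-bromophenyl gives no change at the digits printed from compound 3 to compound 4 (within the scatter). Among the compounds shown here, this is the first comparison here between two compounds that differ in one place, and it shows that, on this aromatic carbon para to a large group, fluoro and bromo cannot be told apart in this measurement. The earlier compounds differ in several places at once, so they could not show this, and nothing measured here explains why the two halogens give the same reading.

On these data alone, whether this carbon accepts a group of a different kind, such as an amine or a carboxylic acid, remains open, as does the effect of a plain hydrogen there. One pair also speaks only for the core of compound 3, so the same exchange might read differently on another core.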